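The source may hold more compounds than are shown below. What is called first, only, known or untested is meant among the compounds shown, and "the series" means these compounds.

Values so far in a functional assay on NCI-H460 cells (Homo sapiens) for cytotoxicity, read by MTT assay, with a stated time of 96 h; a higher number here means a weaker inhibitor, a lower number a stronger inhibitor
- compound 1 `COc1ncc(-c2cc(OC3CCCCC3)c3nc(N)nc(C)c3c2)cc1NS(=O)(=O)c1ccc(F)cc1F` gives 96 nM
- compound 2 `COc1ncc(-c2cc(OC3CCC(F)(F)CC3)c3nc(N)nc(C)c3c2)cc1NS(=O)(=O)c1ccc(F)cc1F` gives 83 nM

Compound 2 stands level with compound 1 on these numbers. The gap is a 1.2-fold lower number from compound 1 to compound 2 (0.06 log units; within the scatter) and marks no real difference between them.

The next compound is compound 3 `COc1ncc(-c2cc(OC3CCN(C)CC3)c3nc(N)nc(C)c3c2)cc1NS(=O)(=O)c1ccc(F)cc1F`, which has 1-methylpiperidin-4-yl in place of 4,4-difluorocyclohexyl on an oxygen on an aromatic ring. The counted difference is 1-methylpiperidin-4-yl in place of 4,4-difluorocyclohexyl on an oxygen on an aromatic ring and the shared core stays the same.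

Within the data shown here, only the one measured step bears on this change, since it falls at the same place, and it lies within the scatter. Among the measured compounds shown here, compound 1 and compound 2 both carry a six-membered non-aromatic ring of carbon only there, so no measured compound shows a ring with a hetero atom at this place. The data therefore give weak guidance. In this assay a small change is expected, leaning slightly towards a higher number, though that direction is poorly supported. The expected change is a 1.6-fold higher number from compound 2 to compound 3 (0.19 log units; within the scatter) and may not exceed the scatter. The estimate for compound 3 is 130 nM with an expected range of 40 nM to 400 nM.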

Compound 3, half-maximal inhibitory concentration: 660 nM
Estimate against measurement, compound 3: 5.1-fold (0.71 log units) below; the measured number lies above the stated range.
By their numbers in this assay, from the lowest: compounds 2 and 1 (each within the scatter of the next); then compound 3.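

This position responds to the group on the oxygen after all, since in this assay the change to 1-methylpiperidin-4-yl gives an 8.0-fold higher number from compound 2 to compound 3 (0.90 log units; beyond the scatter) and the same group set against cyclohexyl gives a 6.9-fold higher number from compound 1 to compound 3 (0.84 log units; beyond the scatter) in the same direction. Among these compounds, the two rings of carbon only in compound 1 and compound 2 stand level, so the earlier pair showed no response here, and the first ring with a hetero atom at this place is also the first group to move the number beyond the scatter. Nothing available explains the rise, and the numbers record its size only.

Compound 3 brings in the ring nitrogen and the methyl on it together, so the compounds shown cannot assign the change to either one. The unsubstituted piperidin-4-yl would separate the methyl from the ring nitrogen, and tetrahydropyran-4-yl, with a ring oxygen in place of the nitrogen, would show whether a hetero atom at this place is enough to raise the number or whether the amine is needed.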